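A few compounds are considered here, and "the series" means these few. Any claim that something is new, unique, unknown or untested is made for them only; others in the source may bear on it.

Measured compounds, with their numbers in an ADME assay on A549 cells (Homo sapiens) for cytotoxicity, read by resazurin assay, with a stated time of 48 h; on this read-out lower numbers stand for higher toxicity in this test and higher numbers for lower toxicity in this test:

- compound 1 `CC(C)CNc1ccc(NC(=O)c2cc(Cl)ccc2O)c(Cl)c1`: 60000 nM
- compound 2 `O=C(Nc1ccc(NCc2ccccc2)cc1Cl)c1cc(Cl)ccc1O`: 19700 nM
- compound 3 `O=C(Nc1ccc(NCc2ccc(Cl)cc2)cc1Cl)c1cc(Cl)ccc1O`: 59700 nM

Compound 3 sits second highest of the three numbers; its number and that of compound 1 lie within the scatter of each other, while compound 2 gives a number that is lower, the step of a 3.0-fold higher number from compound 2 to compound 3 (0.48 log units; beyond the scatter) being beyond the scatter. The two steps that bear on the place in question are a 1.0-fold lower number from compound 1 to compound 3 (0.00 log units; within the scatter) and a 3.0-fold lower number from compound 1 to compound 2 (0.48 log units; beyond the scatter), both changes on the saturated chain carbon bound to a nitrogen on an aromatic ring.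

Compound 4 `O=C(Nc1ccc(NCc2ccc(Br)s2)cc1Cl)c1cc(Cl)ccc1O` is not yet measured. It differs from compound 3 by 5-bromothiophen-2-yl in place of 4-chlorophenyl on a saturated chain carbon bound to a nitrogen on an aromatic ring. Within the data shown here, no measured step introduces a five-membered ring with a hetero atom at this place, so the only guide is that changes here have so far moved the number by at most a modest amount, and in one case not beyond the scatter. A small step in this assay is therefore expected, with a slight lean toward a lower number, and possibly none beyond the scatter; the expected step is a 1.5-fold lower number from compound 3 to compound 4 (0.17 log units; within the scatter). Compound 4 is estimated at 40000 nM, within a range of 15000 nM to 100000 nM.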

Compound 4, half-maximal cytotoxic concentration: 20700 nM
Compound 4: the middle estimate sits 1.9-fold (0.29 log units) above what was measured; low and high end bracket the measured number.
By their numbers in this assay, from the lowest: compounds 2 and 4 (each within the scatter of the next); then compounds 3 and 1 (each within the scatter of the next).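

In this assay, 5-bromothiophen-2-yl brings the first five-membered aromatic ring with a hetero atom to this place, on a saturated chain carbon bound to a nitrogen on an aromatic ring, and a 2.9-fold lower number from compound 3 to compound 4 (0.46 log units; beyond the scatter) shows that the number held by 4-chlorophenyl does not carry over to this halogen-bearing ring. Against phenyl the same change gives a 1.1-fold higher number from compound 2 to compound 4 (0.02 log units; within the scatter) and against isopropyl it gives a 2.9-fold lower number from compound 1 to compound 4 (0.46 log units; beyond the scatter) so compound 4 falls within the scatter of compound 2 and apart from compound 1 and compound 3, and a halogen on the aromatic ring therefore does not by itself go with the higher number at this place. Nothing shown gives a reason for these steps.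

The compounds shown do not separate the contribution of the thiophene ring from that of the bromine, a split that would need thiophen-2-yl and 4-bromophenyl at this same place. Also open, on these data alone, is how this assay would read with an amine or a carboxylic acid on the group at this place, since every aromatic group here carries either a halogen or nothing.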